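A few compounds are considered here, and "the series" means these few. Any claim that something is new, unique, unknown or untested is made for them only; others in the source may bear on it.

Measured so far in a functional assay on CHO-K1 cells for antagonist activity at transient receptor potential cation channel subfamily V member 1 (Homo sapiens), read by FLIPR; on this read-out lower numbers stand for stronger inhibition and higher numbers for weaker inhibition:
- compound 1 `CC1CCC(Nc2nc(C(F)(F)F)ccc2CNC(=O)C(C)c2ccc(NS(C)(=O)=O)c(F)c2)CC1`: 27.2 nM
- compound 2 `CC(C(=O)NCc1ccc(C(F)(F)F)nc1N1CCC(Cc2cc(F)cc(F)c2)CC1)c1ccc(NS(C)(=O)=O)c(F)c1`: 0.4 nM
- compound 3 `CC(C(=O)NCc1ccc(C(F)(F)F)nc1N1CCC(=O)CC1)c1ccc(NS(C)(=O)=O)c(F)c1`: 91 nM

Compound 1 stands second highest of the three numbers. Among the measured compounds shown here, its nearest neighbour is compound 3, which differs from it by a 3.3-fold higher number from compound 1 to compound 3 (0.52 log units; beyond the scatter); the furthest is compound 2, whose number lies far lower, though no single-point step connects the two.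

Compound 4 `COC1CCN(c2nc(C(F)(F)F)ccc2CNC(=O)C(C)c2ccc(NS(C)(=O)=O)c(F)c2)CC1` is the next member. It differs from compound 1 as follows: 4-methoxypiperidin-1-yl in place of (4-methylcyclohexyl)amino on an aromatic carbon

For the measured compounds named here, the one measured step that bears on this change is the one from compound 1 to compound 3, where a 4-oxopiperidin-1-yl also replaced the (4-methylcyclohexyl)amino group on the same aromatic carbon and the number rose by a 3.3-fold higher number from compound 1 to compound 3 (0.52 log units; beyond the scatter). Compound 4 carries a 4-methoxypiperidin-1-yl in that position, a ring of the same type as in compound 3 but with a different 4-substituent. A rise of similar or somewhat smaller size is therefore expected in this assay, in the direction of weaker inhibition, with a fair chance that it stays within the scatter.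

For compound 4 the expected step from compound 1 is a 2.0-fold higher number from compound 1 to compound 4 (0.31 log units; beyond the scatter), and the estimate in this assay is 55 nM, with a range from 18 nM to 170 nM.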

Compound 4, inhibition constant: 2.4 nM
Compound 4: middle estimate off by 23-fold (1.36 log units), on the high side, outside the stated range (below it).
By their numbers in this assay, from the lowest: compound 2; then compound 4; then compound 1; then compound 3.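

In this assay, replacing the group on this aromatic carbon next to the ring nitrogen need not weaken inhibition: 4-methoxypiperidin-1-yl in place of (4-methylcyclohexyl)amino gives the opposite direction (an 11-fold lower number from compound 1 to compound 4 (1.05 log units; beyond the scatter)) to 4-oxopiperidin-1-yl (a 3.3-fold higher number from compound 1 to compound 3 (0.52 log units; beyond the scatter)), and the hydrogen-bond donor of the leaving group is not needed for a low number in compound 4. The piperidine alone therefore does not set the level, since the 4-substituent separates two otherwise matched compounds by a large step (a 38-fold lower number from compound 3 to compound 4 (1.58 log units; beyond the scatter)). Methoxy still falls short of 3,5-difluorobenzyl on the same saturated ring carbon (a 6.0-fold higher number from compound 2 to compound 4 (0.78 log units; beyond the scatter)), so low numbers are reached with substituents as different as these, while the 4-oxo compound stands apart. No measurement at hand gives a cause for any of these steps.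

On these data alone, it remains open whether the ether oxygen of the methoxy group matters, or whether a 4-hydroxy, 4-ethoxy or 4-methyl group on the piperidin-1-yl ring would do the same. Also open, as far as these compounds go, is whether a morpholin-4-yl group at this position would follow compound 4 or compound 3.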